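The source may report more compounds than this note shows. Statements on the series, on what has been measured and on what is new or still open speak of the compounds shown alone.

Measured so far:
compound 1 `Cc1nc2nc(-c3ccccc3)nn2c(-c2ccc(Cl)cc2Cl)c1CN` — > 30000 nM
compound 2 `Cc1nc2nc(N3CCCC3)nn2c(-c2ccc(Cl)cc2Cl)c1CN` — > 30000 nM

In an assay on isolated protein for inhibition of Dipeptidyl peptidase 9 (Homo sapiens) (a higher number here means a weaker inhibitor, a lower number a stronger inhibitor), compound 1 gives > 30000 nM, a limit of the assay rather than a number. In this assay compound 2 gives > 30000 nM, likewise a limit. The step that the two limits leave unreadable from compound 1 to compound 2 therefore cannot be read, and compound 2 stands at the limit of > 30000 nM in this assay, at which 2 of the 2 values shown sit.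

Compound 3 `Cc1nc2nc(C(=O)Nc3ccccc3)nn2c(-c2ccc(Cl)cc2Cl)c1CN` differs from compound 2 by phenylcarbamoyl in place of pyrrolidin-1-yl on an aromatic carbon. Within the data shown here, no measured step bears on this change in a readable way, so no direction is expected beyond the scatter. Expected is a step of a number no higher from compound 2 to compound 3 (the limit leaves the size open). Compound 3 is estimated at 30000 nM, range 8000 nM to 100000 nM, most likely again only a limit.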

Compound 3, inhibition constant: > 10000 nM
Compound 3 was reported as a limit; the forecaster's own chance of this, stated with the estimate: 75%; the middle value lies beyond the limit too.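

Compound 3 gives > 10000 nM in this assay, a limit of the assay. Among these compounds, with compound 1 and compound 2 also at limits, no step among the three can be read. The compounds shown leave open how far any of these groups shifts inhibition.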